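Amide nitrogen substituent change from compound 1 to compound 3

The compounds below may be only part of what the source reports. "The series", "measured", "known", "first", "only" and "open" are said of these compounds alone.

Among the compounds with values here, compound 1 `Nc1sc(-c2ccc(Cl)cc2)c(-c2ccc(Cl)cc2)c1C(=O)NC1CCC(O)CC1` is the only member of the set with a reported number and so is the sole reference point. In a functional assay on A549 cells (Homo sapiens) for inhibition, read by sulforhodamine B assay, with a stated time of 72 h (on this read-out higher numbers stand for weaker inhibition and lower numbers for stronger inhibition), compound 1 gives 250 nM. Compound 2 `CS(=O)(=O)Nc1sc(-c2ccc(Cl)cc2)c(-c2ccc(Cl)cc2)c1C(=O)NC1CC1` has no result in this assay, recorded as "not determined" (no result reported), and contributes nothing to the comparison. Compound 3 `Nc1sc(-c2ccc(Cl)cc2)c(-c2ccc(Cl)cc2)c1C(=O)NC1CCCC1` is not yet measured. The change from compound 1 to compound 3 is cyclopentyl in place of 4-hydroxycyclohexyl on an amide-type nitrogen. Within the data shown here, no step between measured compounds is available, so the size of this change is not anchored by any pair in the set. A modest step in this assay is expected, toward weaker inhibition or none beyond the scatter. The expected step of a 1.4-fold higher number from compound 1 to compound 3 (0.15 log units; within the scatter) is estimated from compound 1 and its value 250 nM alone. For compound 3 the expected value in this assay is estimated at 350 nM, with a range from 100 nM to 1200 nM.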

Compound 3, half-maximal inhibitory concentration: 6790 nM
Estimate against measurement, compound 3: 19-fold (1.29 log units) below, and the stated range ends below it.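

The amide nitrogen substituent turns out to be a sensitive position on the shared core: in this assay, cyclopentyl in place of 4-hydroxycyclohexyl gives a 27-fold higher number from compound 1 to compound 3 (1.43 log units; beyond the scatter) as a large step toward weaker inhibition. The two groups differ in more than one respect, since a six-membered ring carrying a hydroxy group gives way to a five-membered ring of carbon only, and this single step does not separate those features. Nothing available bears on the reason for the step.

Open, on these data alone, is whether the step follows the hydroxy group or the ring size, a question that plain cyclohexyl and hydroxycyclopentyl would address. Also open, as far as these compounds go, is how an amine or a carboxylic acid in place of the hydroxy group on the cyclohexyl ring would read in this assay.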